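Replacing a dimethylaminomethyl arm with phenyl: an expected flat step

The source may report more compounds than this note shows. Statements on the series, on what has been measured and on what is new or still open speak of the compounds shown alone.

Measured so far:
- compound 1, `CCN(Cc1cccc(Br)c1)c1ccc(C(=O)N2CCc3ccc(OS(N)(=O)=O)cc3C2)cc1`: 1.93
- compound 2, `CN(C)CCN(CCN(C)C)c1ccc(C(=O)N2CCc3ccc(OS(N)(=O)=O)cc3C2)cc1`: 1.93
- compound 3, `CN(CCN1CCCCC1)c1ccc(C(=O)N2CCc3ccc(OS(N)(=O)=O)cc3C2)cc1`: 1.93

In a physicochemical assay for lipophilicity (a higher number here means a more lipophilic compound, a lower number a more polar compound), compound 2 stands level with compounds 1 and 3. The steps of no change at the digits printed from compound 1 to compound 2 (within the scatter), no change at the digits printed from compound 1 to compound 3 (within the scatter) and no change at the digits printed from compound 2 to compound 3 (within the scatter) all stay within the scatter, although each swaps one whole amino group for a very different one on the aromatic carbon.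

Compound 4, `CN(C)CCN(Cc1ccccc1)c1ccc(C(=O)N2CCc3ccc(OS(N)(=O)=O)cc3C2)cc1`, is not yet measured. It differs from compound 2 in one place: phenyl in place of (dimethylamino)methyl on a saturated chain carbon bound to a nitrogen on an aromatic ring. None of the three measured steps makes exactly this change, but compound 1 already carries a benzyl-type group and compound 2 carries two dimethylaminoethyl groups, and both read the same.

The step of a number 0.02 log units higher from compound 2 to compound 4 (within the scatter) is therefore expected to lie within the scatter. Compound 4 is estimated at 1.95, between 1.6 and 2.3.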

Compound 4, partition coefficient: 1.93
The estimate for compound 4 lay 0.02 log units above the measured number, and the stated range covers the measured number.
By their numbers in this assay, from the lowest: compounds 1, 2, 3 and 4 (each within the scatter of the next).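

In this assay the change to phenyl in place of (dimethylamino)methyl on a saturated chain carbon bound to a nitrogen on an aromatic ring gives no change at the digits printed from compound 2 to compound 4 (within the scatter) and extends the flat picture to a smaller edit than the earlier swaps of whole amino groups. Here only one arm differs, losing a nitrogen and gaining a six-membered aromatic ring of carbon only, and the reading stays level. Nothing measured here explains this. Going by these compounds, whether a carboxylic acid in place of the phenyl would also read level remains open, as does the effect of a longer chain at this place.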